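The source may hold more compounds than are shown below. What is called first, only, known or untested is meant among the compounds shown, and "the series" means these compounds.

Compound 2 `COc1cc(-c2nn(-c3cccc(NC(=O)Nc4ccc(Cl)c(Cl)c4)c3)cc2-c2ccncc2)ccc1Cl` gives 1140 nM in a functional assay on SK-MEL-2 cells (Homo sapiens) for inhibition, read by sulforhodamine B assay, with a stated time of 48 h; on this read-out lower numbers stand for stronger inhibition of growth and higher numbers for weaker inhibition of growth. Among the three measured compounds this is the highest number, yet its gaps to the other two lie within the scatter. Compound 1 `COc1cc(-c2nn(-c3cccc(NC(=O)Nc4cc(C(F)(F)F)cc(C(F)(F)F)c4)c3)cc2-c2ccncc2)ccc1Cl`, which carries a differently substituted phenyl at the far end of the carbonyl linker, gives 1020 nM in this assay. Among the measured compounds shown here, compound 3 `O=C(Nc1cccc(-n2cc(-c3ccncc3)c(-c3ccc(Cl)c(O)c3)n2)c1)Nc1ccc(Cl)c(Cl)c1` gives 1030 nM in this assay, and the only measured single-point step, a 1.1-fold lower number from compound 2 to compound 3 (0.04 log units; within the scatter), stays within the scatter.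

Compound 4 `COc1cc(-c2nn(-c3cccc(NC(=O)c4ccc(Cl)c(C(F)(F)F)c4)c3)cc2-c2ccncc2)ccc1Cl` differs from compound 2 in one place: 4-chloro-3-(trifluoromethyl)phenyl in place of (3,4-dichlorophenyl)amino on a carbonyl carbon. For the measured compounds named here, no measured step touches this part of the molecule, so none bears on it directly. Going by the values given here, what the data do show is that the numbers for compound 1 and compound 2 sit close together although their terminal phenyl rings carry different substituents, and that the one measured step is small. Going by these compounds, on that basis the expected step of a 1.0-fold lower number from compound 2 to compound 4 (0.02 log units; within the scatter) is none beyond the scatter, with a broad range because the linker itself is untested. For compound 4 the estimated value is 1100 nM, expected to fall between 400 nM and 3000 nM.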

Compound 4, concentration for 50% growth inhibition: 1900 nM
Compound 4: middle estimate off by 1.7-fold (0.24 log units), on the low side, and the stated range covers the measured number.
By their numbers in this assay, from the lowest: compounds 1, 3, 2 and 4 (each within the scatter of the next).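

In this assay, the change at this carbonyl carbon gives a 1.7-fold higher number from compound 2 to compound 4 (0.22 log units; within the scatter), so this position accepts 4-chloro-3-(trifluoromethyl)phenyl in place of (3,4-dichlorophenyl)amino with no shift beyond the scatter. This holds even though the group that leaves carries a hydrogen-bond donor and the group that enters carries none, so that donor is not needed to keep the number in this range, at least in this pair. No measurement here accounts for this step.

The linking nitrogen and the ring substituents change together, so the step cannot say what each contributes alone. Going by these compounds, it also remains open whether a cyclohexyl ring or a longer chain such as benzyl on the carbonyl carbon would keep the number in this range.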